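Aryl swap on the shared core: metabolic stability outlook

The compounds below may be only part of what the source reports. "The series", "measured", "known", "first", "only" and "open" are said of these compounds alone.

Compound 3 `O=S(=O)(c1cccc(F)c1)c1cnc2c(F)cccc2c1-c1ccc(Cl)cc1` stands second highest of the three numbers in an ADME assay on microsomes from liver (Homo sapiens) for metabolic stability, tested at 2.5 uM (a lower number here means slower removal, a higher number faster removal of the compound), giving 0.62 mL/min. Compound 2 `COc1cccc(-c2c(S(=O)(=O)c3ccc(F)cc3)cnc3c(F)cccc23)c1` gives 2.23 mL/min, and compound 1 `O=S(=O)(c1ccc(F)c(Cl)c1)c1cnc2c(F)cccc2c1-c1ccc(Cl)cc1` gives 0.01 mL/min. For the measured compounds named here, the only step between measured neighbours, a 62-fold higher number from compound 1 to compound 3 (1.79 log units; beyond the scatter), concerns the group on the sulfonyl sulfur, not the aromatic carbon changed here. Compound 4 `COc1cccc(-c2c(S(=O)(=O)c3cccc(F)c3)cnc3c(F)cccc23)c1` differs from compound 3 by 3-methoxyphenyl in place of 4-chlorophenyl on an aromatic carbon. Going by the values given here, no measured step bears directly on this change; compound 2 carries the same 3-methoxyphenyl with a different group on the sulfonyl sulfur, and its value 2.23 mL/min lies above that of compound 3. An upward step in this assay beyond the scatter is therefore expected, a 2.4-fold higher number from compound 3 to compound 4 (0.38 log units; beyond the scatter). Compound 4 is estimated at 1.5 mL/min, with a range from 0.5 mL/min to 4.5 mL/min.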

Compound 4, intrinsic clearance in a liver preparation (reported as CLH), per the amount of preparation that the assay uses: 2.6 mL/min
The estimate for compound 4 lay 1.7-fold (0.24 log units) below the measured number, within the range that was stated.
By their numbers in this assay, from the lowest: compound 1; then compound 3; then compounds 2 and 4 (each within the scatter of the next).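

For the compounds shown here, the step of a 4.2-fold higher number from compound 3 to compound 4 (0.62 log units; beyond the scatter) gives the first direct reading in this assay of 3-methoxyphenyl in place of 4-chlorophenyl on this aromatic carbon, opposite the ring nitrogen. With 3-methoxyphenyl held there, 3-fluorophenyl in place of 4-fluorophenyl on the sulfonyl sulfur gives a 1.2-fold higher number from compound 2 to compound 4 (0.07 log units; within the scatter) and so no readable change. Nothing at hand accounts for the step at the aromatic carbon. The compounds shown leave open how an amine or a carboxylic acid on this aromatic carbon would stand in this assay in place of the aryl ring. Also open, on these data alone, is whether 3-chloro-4-fluorophenyl on the sulfonyl sulfur would lower the number with 3-methoxyphenyl on the core.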